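This account rests on a few compounds, and the source may have more. Where it says the series, first, only, none or still open, it means among the compounds named here.

Working notes on the series

Compound 1 `COC(=O)[C@@]1(C)CCC=C2[C@@H]1CC[C@@H](C)[C@]2(C)Cc1c(C)[nH]c2ccc(Br)cc12` carries a bromo group on its indole-bearing core; compound 2 `COC(=O)[C@@]1(C)CCC=C2[C@@H]1CC[C@@H](C)[C@]2(C)Cc1c(C)[nH]c2ccc(Cl)cc12` has the same core with the change (chloro in place of bromo on an aromatic carbon). In a functional assay on T47D cells (Homo sapiens) for inhibition, read by sulforhodamine B assay, with a stated time of 48 h (on this read-out lower numbers stand for stronger inhibition of growth and higher numbers for weaker inhibition of growth), compound 1 gives 16000 nM. In this assay compound 2 gives 17000 nM, so that a 1.1-fold higher number from compound 1 to compound 2 (0.03 log units; within the scatter).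

Compound 3 `COC(=O)[C@@]1(C)CC[C@@H]2C3=C1CC[C@@H](C)[C@]3(C)C[C@@H]1c3cc(Br)ccc3N[C@H]21` is built on a different core, and the difference between the two cores is not broken down here. In this assay compound 3 gives 31000 nM; set against compound 1 and compound 2, the three values sit close together.

Compound 4 `COC(=O)[C@@]1(C)CC[C@@H]2C3=C1CC[C@@H](C)[C@]3(C)C[C@@H]1c3cc(Cl)ccc3N[C@H]21` is not yet measured. It follows from compound 3 by chloro in place of bromo on an aromatic carbon. This is the same kind of change as that between compound 1 and compound 2, not the same: in compound 1 and compound 2 the aromatic carbon belongs to a fused or bridged system of two rings, whereas in compound 3 and compound 4 it belongs to a fused or bridged system of five rings; in both pairs the carbon is meta to a fused ring and para to a fused ring.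

For compound 4 the step of a 1.1-fold higher number from compound 3 to compound 4 (0.03 log units; within the scatter) is expected, resting on the observation that a 1.1-fold higher number from compound 1 to compound 2 (0.03 log units; within the scatter) amounted to little. The estimate for compound 4 in this assay is therefore 33000 nM, with a plausible range from 16000 nM to 66000 nM.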

Compound 4, concentration for 50% growth inhibition: 28000 nM
Beside the measured number, compound 4's estimate is 1.2-fold (0.07 log units) above it; the measured number falls inside the stated range.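

Exchanging bromo for chloro on the aromatic carbon of the second core, in this assay, gives a 1.1-fold lower number from compound 3 to compound 4 (0.04 log units; within the scatter). Set beside the same exchange on the first core, the step reads alike on both cores: the same change on two cores in this assay, a 1.1-fold higher number (0.03 log units; within the scatter) from compound 1 to compound 2 and a 1.1-fold lower number (0.04 log units; within the scatter) from compound 3 to compound 4, 1.2-fold (0.07 log units) apart, within the scatter of two such steps This shows only that the exchange leaves the growth-inhibition number unchanged within the scatter on each of these two cores; it does not show that steps of larger size would carry from one core to the other, as neither pair contains such a step, and two pairs of one halogen exchange at one place, in one cell assay, make no general rule for the series.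

The compounds shown leave open what other groups would do on this aromatic carbon, for example an amine, a carboxylic acid, a methoxy group or a plain hydrogen in place of the halogen, and whether such a group would give a step beyond the scatter and then give the same step on both cores. Also open, going by these compounds, is whether any change elsewhere on these cores, such as a carboxylic acid in place of the methyl ester, would move the number on either core.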